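Replacing the acid chain of compound 2 with a basic one

The source may report more compounds than this note shows. Statements on the series, on what has been measured and on what is new or still open speak of the compounds shown alone.

Compound 1 `C=C(C)C(=O)Nc1cccc(-c2nc3ccccc3s2)c1` in an ADME assay on HepG2 cells (Homo sapiens) for inhibition, with a stated time of 72 h (on this read-out lower numbers stand for an effect already at smaller amounts and higher numbers for an effect only at larger amounts of compound), reaches only an assay limit, > 25000 nM. Compound 2 `O=C(O)/C=C/C(=O)Nc1cccc(-c2nc3ccccc3s2)c1` likewise stops at the limit of this assay, > 25000 nM. The step that the two limits leave unreadable from compound 1 to compound 2 is therefore unreadable, and the limit of > 25000 nM in this assay, at which 2 of the 2 values shown sit, is the whole of the evidence, so compound 2 stands at the limit with no numbered neighbour. Compound 3 `CN(C)CCC(=O)Nc1cccc(-c2nc3ccccc3s2)c1` differs from compound 2 by 2-(dimethylamino)ethyl in place of 2-carboxyethenyl on a carbonyl carbon. Among the measured compounds shown here, no measured step bears on this change, so the expected step is a number no higher from compound 2 to compound 3 (the limit leaves the size open), none beyond the scatter. Compound 3 is accordingly estimated at 25000 nM, within 8000 nM to 80000 nM.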

Compound 3, half-maximal effective concentration: 21000 nM
Compound 3: the middle estimate sits 1.2-fold (0.08 log units) above what was measured; the measured number falls inside the stated range.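

Among the compounds shown here, with 2-(dimethylamino)ethyl on the carbonyl carbon, compound 3 gives the first true number in this assay, so this position can register a value rather than only a limit. The steps read an at least 1.1-fold lower number from compound 2 to compound 3 (0.07 log units; that floor lies within the scatter) and an at least 1.1-fold lower number from compound 1 to compound 3 (0.07 log units; that floor lies within the scatter), so neither shows a change beyond the scatter. The evidence still rests largely on limits: the limit of > 25000 nM in this assay, at which 2 of the 3 values shown sit.

The compounds shown leave open whether the amine or the loss of the double bond matters, which a saturated carboxylic acid chain would help separate. Going by these compounds, how a primary amine or a longer chain would read also remains open.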